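Notes on compound 4: benzyl replacing 4-chlorophenyl

The compounds below may be only part of what the source reports. "The series", "measured", "known", "first", "only" and "open" are said of these compounds alone.

Three members of the series have been read in a functional assay on DU-145 cells (Homo sapiens) for cytotoxicity, read by MTT assay, with a stated time of 48 h; on this read-out lower numbers stand for stronger inhibition and higher numbers for weaker inhibition. Compound 1 `Cc1ccc(S(=O)(=O)/N=C(/CCNC2=CC(=O)c3ccccc3C2=O)Nc2ccc(Cl)cc2)cc1` gives 32400 nM and stands highest of the three. Compound 2 `Cc1ccc(S(=O)(=O)/N=C(/CCNC2=CC(=O)c3ccccc3C2=O)Nc2ccccc2I)cc1` gives 11700 nM, and compound 3 `Cc1ccc(S(=O)(=O)/N=C(/CCNC2=CC(=O)c3ccccc3C2=O)Nc2ccc(F)c(F)c2)cc1` gives 12900 nM; the two lie within the scatter of each other, a 1.1-fold higher number from compound 2 to compound 3 (0.04 log units; within the scatter).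

Compound 4 `Cc1ccc(S(=O)(=O)/N=C(/CCNC2=CC(=O)c3ccccc3C2=O)NCc2ccccc2)cc1` has not been measured. It differs from compound 1 by benzyl in place of 4-chlorophenyl on an amine nitrogen. Among the measured compounds shown here, no measured step swaps an aryl for a benzyl, so the only bearing comes from the two changes at the same nitrogen: a 2.8-fold lower number from compound 1 to compound 2 (0.44 log units; beyond the scatter) and a 2.5-fold lower number from compound 1 to compound 3 (0.40 log units; beyond the scatter), both modest lower numbers. Those steps vary substituents on the same kind of ring and cannot be read straight onto a benzyl, so compound 4 is expected near compound 1, with at most a modest step.

The step of a 1.5-fold lower number from compound 1 to compound 4 (0.17 log units; within the scatter) is the expected outcome. Compound 4 is estimated at 22000 nM, with a range from 7000 nM to 70000 nM.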

Compound 4, half-maximal inhibitory concentration: 9120 nM
Estimate against measurement, compound 4: 2.4-fold (0.38 log units) above, and the stated range covers the measured number.
By their numbers in this assay, from the lowest: compounds 4, 2 and 3 (each within the scatter of the next); then compound 1.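

In this assay, benzyl in place of 4-chlorophenyl on the amine nitrogen gives a 3.6-fold lower number from compound 1 to compound 4 (0.55 log units; beyond the scatter), so lower numbers at this position are not confined to substituted phenyl groups. Compound 4 does not separate from the other two, with a 1.4-fold lower number from compound 3 to compound 4 (0.15 log units; within the scatter) and a 1.3-fold lower number from compound 2 to compound 4 (0.11 log units; within the scatter), which leaves compounds 2, 3 and 4 together and only compound 1 apart from all three. No supporting data bear on this result.

Still open, from the compounds shown here alone, is whether a 4-chlorobenzyl group would read with compound 4 or with compound 1, which would separate the part played by the chlorine from that played by the benzyl. The compounds shown also do not say how a longer chain such as phenethyl, or a cyclohexylmethyl group without an aromatic ring, would read at this nitrogen.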